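Swapping Phenyl for Pyridin-4-yl in a Hydroxamic Acid Amide

The compounds below may be only part of what the source reports. "The series", "measured", "known", "first", "only" and "open" are said of these compounds alone.

Among the compounds with values here, compound 1 `O=C(CCCCC[C@H](NC(=O)c1ccc(Br)cc1)C(=O)NCc1ccccc1)NO` is one of two compounds measured in a functional assay on NFF cells (Homo sapiens) for antiproliferative activity (on this read-out lower numbers stand for stronger inhibition and higher numbers for weaker inhibition), where compound 1 gives 5860 nM. That is the highest of the two numbers: compound 2 `O=C(CCCCC[C@H](NC(=O)c1ccc(C(F)(F)F)cc1)C(=O)NCc1ccccc1)NO`, which carries trifluoromethyl in place of bromo on an aromatic carbon, gives 1610 nM, and the step is a 3.6-fold lower number from compound 1 to compound 2 (0.56 log units; beyond the scatter). Compound 3 `O=C(CCCCC[C@H](NC(=O)c1ccc(Br)cc1)C(=O)NCc1ccncc1)NO` has not yet been measured. It differs from compound 1 by pyridin-4-yl in place of phenyl on a saturated chain carbon bound to an amide-type nitrogen. Within the data shown here, the single measured step concerns bromo on an aromatic carbon of the shared core and not the benzylcarbamoyl part, so no measured step bears directly on this change, and the data give no guide to its size. In the absence of such a guide, the expectation for compound 3 is a number close to that of compound 1, with no step beyond the scatter in either direction, which as an estimate means a 1.2-fold lower number from compound 1 to compound 3 (0.07 log units; within the scatter). Compound 3 is therefore estimated at 5000 nM, expected to fall between 1800 nM and 14000 nM.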

Compound 3, half-maximal inhibitory concentration: 5240 nM
For compound 3 the middle estimate is 1.0-fold (0.02 log units) below the measured one; low and high end bracket the measured number.
By their numbers in this assay, from the lowest: compound 2; then compounds 3 and 1 (each within the scatter of the next).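

Within the data shown here, compound 3 gives the first reading at the benzylcarbamoyl end of the molecule, since the earlier step concerned only the bromo group on the other side of the shared core. In this assay, pyridin-4-yl in place of phenyl gives a 1.1-fold lower number from compound 1 to compound 3 (0.05 log units; within the scatter), so exchanging a ring of carbon only for one holding a nitrogen, which adds one hydrogen-bond acceptor by the count, leaves the number unmoved beyond normal repeat variation, at least with bromo on the core. No accompanying measurement offers an explanation for this outcome.

From the compounds shown here alone, whether the same exchange would be equally silent on the trifluoromethyl-bearing core of compound 2 remains open, as a single pair cannot show whether the outcome carries over from one core to another. Also open, going by these compounds, is whether this end of the molecule would stay as undemanding with a different kind of group, such as a carboxylic acid or an amine on the ring, or a longer chain in place of benzyl.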